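The compounds below may be only part of what the source reports. "The series", "measured", "known", "first", "only" and "open" are said of these compounds alone.

Compound 1 `COc1cccc(C(=O)Oc2cc3c(cc2C)[C@@H](C(C)C)CC=C3C)c1`: 16.3%
Compound 2 `COc1ccc(C(=O)Oc2cc3c(C)ccc(C(C)C)c3cc2C)cc1`: 10.4%

Both were tested in a functional assay on PC-3 cells (Homo sapiens) for antiproliferative activity, read by sulforhodamine B assay, with a stated time of 48 h, tested at 50 uM; a lower number here means less inhibition, a higher number more inhibition at the concentration tested (going by the name of the read-out). Compound 1 gives 16.3%, and compound 2 gives 10.4%; the gap between them lies within the usual scatter, so neither stands apart from the other. Compound 3 `CC1=CC[C@H](C(C)C)c2cc(C)c(OC(=O)Nc3ccccc3)cc21` has not yet been measured. It differs from compound 1 in one place: anilino in place of 3-methoxyphenyl on a carbonyl carbon. Going by the values given here, no measured pair shows this change, so its effect is unknown from the data. The expected step, a number 1.3 percentage points lower from compound 1 to compound 3 (within the scatter), is small and points in no firm direction beyond the scatter. Compound 3 is expected to give about 15%, between 3% and 32%.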

Compound 3, a percentage reported as inhibition, at one concentration (the size of the read-out at that concentration, not a potency): 93.2%
Compound 3: middle estimate off by 78.2 percentage points, on the low side; measured number above the stated range.
By their numbers in this assay, from the lowest: compounds 2 and 1 (each within the scatter of the next); then compound 3.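

In this assay putting anilino in place of 3-methoxyphenyl on a carbonyl carbon gives a number 76.9 percentage points higher from compound 1 to compound 3 (beyond the scatter). This position is therefore far from indifferent to what it carries, since a single change on the shared core is enough to move the read-out well beyond the scatter. Nothing measured here accounts for the jump. Still open, from the compounds shown here alone, is whether the ring or the nitrogen link matters, which a cyclohexylamino or benzylamino group on the same carbonyl carbon could help separate. This single pair also cannot show whether the change would act the same way on another core.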